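A few compounds are considered here, and "the series" means these few. Any claim that something is new, unique, unknown or untested is made for them only; others in the source may bear on it.

In an ADME assay on cells (Peritoneal macrophage cell, Mus musculus) for cytotoxicity, read by fluorescence and resazurin assay, with a stated time of 3 days (a lower number here means that less compound is tolerated, a higher number that more compound is tolerated), compound 1 `O=C(NCc1ccccc1)Nc1[nH]nc(-c2ccccn2)c1Cl` gives > 64000 nM as a limit of the assay, not a number. Compound 2 `O=C(Nc1cc(-c2ccccn2)n[nH]1)N1CCC(c2cccc(F)c2)CC1` gives > 45000 nM and that too is only a limit. Among the measured compounds shown here, compound 2 therefore has no numeric reading in this assay and the one other value available is also a limit, so no step between measured compounds can be read.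

Compound 3 `N#Cc1ccc(OC2CCN(C(=O)Nc3cc(-c4ccccn4)n[nH]3)CC2)cc1` carries 4-cyanophenoxy in place of 3-fluorophenyl on a saturated ring carbon of the six-membered non-aromatic ring with 1 nitrogen. The counted difference 4-cyanophenoxy in place of 3-fluorophenyl on a saturated ring carbon is the whole of the change, and the rest of compound 2 stays as it is.

Nothing measured gives a size for such a change in this assay, so no shift in either direction beyond the usual scatter is expected. The estimated step that the limit leaves unreadable from compound 2 to compound 3 is expected to stay within that scatter. This expectation leans on compound 2 with > 45000 nM as a limit. Compound 3 is estimated at 50000 nM with an expected range from 20000 nM to 100000 nM and a reading that may again come back as a limit.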

Compound 3, half-maximal cytotoxic concentration: > 64000 nM
Compound 3: a limit, no number; the forecaster's own chance of this, stated with the estimate: 75%; middle value at least 1.2-fold (0.10 log units) from the limit.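

In this assay compound 2 gives > 45000 nM, a limit and not a number. Compound 3 gives > 64000 nM, also a limit, so no step can be read between compound 2 and compound 3. The compounds shown leave open at what concentration any of them turns cytotoxic, and whether 4-cyanophenoxy in place of 3-fluorophenyl on a saturated ring carbon shifts that concentration.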